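From Dichlorobenzyl to Bromophenyl: What Should Change?

A few compounds are considered here, and "the series" means these few. Any claim that something is new, unique, unknown or untested is made for them only; others in the source may bear on it.

In a functional assay on Huh-7 cells (Homo sapiens) for cytotoxicity, read by cell counting, with a stated time of 48 h (a higher number here means a weaker inhibitor, a lower number a stronger inhibitor), compound 1 `Cc1ccc(-n2cc(COc3cccc4cnc(Nc5cccc(Cl)c5)nc34)nn2)c([N+](=O)[O-])c1` gives 25000 nM, compound 2 `COc1ccccc1-n1cc(COc2cccc3cnc(Nc4cccc(Cl)c4)nc23)nn1` gives 7000 nM and compound 3 `Clc1cccc(Nc2ncc3cccc(OCc4cn(Cc5c(Cl)cccc5Cl)nn4)c3n2)c1` gives 7000 nM. Compound 3 thus sits level with compound 2, and together they have the lowest of the three numbers. Compound 4 `Clc1cccc(Nc2ncc3cccc(OCc4cn(-c5ccc(Br)cc5)nn4)c3n2)c1` has 4-bromophenyl in place of 2,6-dichlorobenzyl on an aromatic nitrogen. Three measured steps change this same position. There is a 3.6-fold lower number from compound 1 to compound 2 (0.55 log units; beyond the scatter) and a 3.6-fold lower number from compound 1 to compound 3 (0.55 log units; beyond the scatter), both modest, whereas no change at the digits printed from compound 2 to compound 3 (within the scatter) stays within the scatter. A small move in this assay towards a higher number therefore seems likely, though it may not exceed the scatter. The expected step is a 1.4-fold higher number from compound 3 to compound 4 (0.15 log units; within the scatter). For compound 4 the estimated value is 10000 nM, with an expected range of 4000 nM to 25000 nM.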

Compound 4, half-maximal inhibitory concentration: 14000 nM
Compound 4: the middle estimate sits 1.4-fold (0.15 log units) below what was measured; measured number inside the range.
By their numbers in this assay, from the lowest: compounds 2, 3, 4 and 1 (each within the scatter of the next, the first and the last beyond it).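

In this assay, 4-bromophenyl gives a 2.0-fold higher number from compound 3 to compound 4 (0.30 log units; within the scatter), a 2.0-fold higher number from compound 2 to compound 4 (0.30 log units; within the scatter) and a 1.8-fold lower number from compound 1 to compound 4 (0.25 log units; within the scatter). Compound 4 thus falls within the scatter of all three earlier compounds, so the gap between compound 1 and compounds 2 and 3 no longer splits this set into two clear groups. Nothing available here explains these numbers.

All four compounds carry a six-membered aromatic carbon ring at this position. As far as these compounds go, whether a simple amine or a carboxylic acid on a longer chain would move the number beyond the scatter remains open.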